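Methoxypyridyl in place of cyanophenyl on the acid-bearing ring

A few compounds are considered here, and "the series" means these few. Any claim that something is new, unique, unknown or untested is made for them only; others in the source may bear on it.

Three compounds have numbers in an in vitro assay on HEK385-7 cells for displacement of a labelled ligand from prostaglandin D2 receptor 2 (Homo sapiens); on this read-out lower numbers stand for stronger inhibition and higher numbers for weaker inhibition. Compound 1 `COc1ccc(C(c2ccccn2)c2nc(-c3ccc(Cl)cc3)c(CC(=O)O)s2)cc1` gives 61 nM. Compound 2 `O=C(O)Cc1sc(C(c2ccccc2)c2ccccc2)nc1-c1ccc(F)cc1` gives 8.7 nM. Compound 3 `N#Cc1ccc(-c2nc(C(c3ccc(F)cc3)c3ccc(F)cc3)sc2CC(=O)O)cc1` gives 150 nM, the highest number of the three, and its gap to compound 1 as well as its much wider gap to compound 2 both lie beyond the scatter; among these three compound 3 is therefore the weakest on this read-out.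

Compound 4 `COc1cc(-c2nc(C(c3ccc(F)cc3)c3ccc(F)cc3)sc2CC(=O)O)ccn1` is the next member and is not yet measured in this assay. It differs from compound 3 in one place: 2-methoxypyridin-4-yl in place of 4-cyanophenyl on an aromatic carbon. Among the compounds with values here, the aromatic group on the five-membered ring is the only change, and the two aryl groups on the carbon that bears the large group are kept. Within the data shown here, no measured pair in the set shows this change, so the size of the step can only be guessed from the position of compound 3. Compound 4 is estimated at 100 nM, with a range from 30 nM to 400 nM. This estimate means an expected step of a 1.5-fold lower number from compound 3 to compound 4 (0.18 log units; within the scatter), toward a lower number, but small enough that it may stay within the scatter.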

Compound 4, half-maximal inhibitory concentration: 29 nM
Estimate against measurement, compound 4: 3.4-fold (0.54 log units) above; the whole stated range lies above it.
By their numbers in this assay, from the lowest: compound 2; then compound 4; then compound 1; then compound 3.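

In this assay, 2-methoxypyridin-4-yl in place of 4-cyanophenyl on the aromatic carbon next to the ring nitrogen gives a 5.2-fold lower number from compound 3 to compound 4 (0.71 log units; beyond the scatter) with the two aryl groups on the neighbouring large group kept unchanged. Within the data shown here, this is the first single-place step in the set, and it shows that this position responds to the choice of aromatic group, which compounds 1, 2 and 3, all differing in more than one place, could not show. No supporting measurement bears on the reason for this step.

From the compounds shown here alone, the change removes the nitrile and brings in a ring nitrogen and a methoxy group at once, so the share of each in the step remains open. An unsubstituted pyridin-4-yl group or a methoxyphenyl group at this position would separate these contributions.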